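Bromo for methoxy on a shared core, toxicity expected steady

The source may report more compounds than this note shows. Statements on the series, on what has been measured and on what is new or still open speak of the compounds shown alone.

Compound 1 `COc1ccc(-c2c(C)nc(S)n2Nc2cccc(Cl)c2)cc1` gives 38700 nM in a functional assay on MT4 cells (Homo sapiens) for cytotoxicity (on this read-out lower numbers stand for higher toxicity in this test and higher numbers for lower toxicity in this test), the lowest of the two numbers recorded. Compound 2 `CC1N=C(S)N(Nc2cccc(Cl)c2)C1C(=O)O` gives 266000 nM in this assay, a higher number beyond the scatter; the two structures differ in many places, so only their values are compared. Compound 3 `Cc1nc(S)n(Nc2cccc(Cl)c2)c1-c1ccc(Br)cc1` carries bromo in place of methoxy on an aromatic carbon, para to a large group. Among the measured compounds shown here, with no comparable step measured, the step from compound 1 to compound 3 is expected to be small, a 1.3-fold lower number from compound 1 to compound 3 (0.11 log units; within the scatter), toward slightly higher toxicity at most. Compound 3 is therefore estimated at 30000 nM, within 10000 nM to 90000 nM.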

Compound 3, half-maximal cytotoxic concentration: 33200 nM
Compound 3: middle estimate off by 1.1-fold (0.04 log units), on the low side, and the stated range covers the measured number.
By their numbers in this assay, from the lowest: compounds 3 and 1 (each within the scatter of the next); then compound 2.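

Bromo in place of methoxy on this aromatic carbon, para to a large group, gives the first one-place comparison here: in this assay the change amounts to a 1.2-fold lower number from compound 1 to compound 3 (0.07 log units; within the scatter). At this position, the two groups cannot be told apart on this read-out, which the differing compounds 1 and 2 could not show. Nothing available gives a reason for this result.

On these data alone, whether an amine, a carboxylic acid or a longer alkoxy chain at this position would also stay within the scatter of compound 1 remains open. So does whether this holds for fluoro or chloro.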